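The source may hold more compounds than are shown below. What is called first, only, known or untested is meant among the compounds shown, and "the series" means these compounds.

Compound 3 `Nc1cc(N)c2nc(-c3ccccc3)c(NCc3ccc(F)cc3)nc2c1` is the shared core bearing a (4-fluorobenzyl)amino group. In a functional assay on SF-539 cells (Homo sapiens) for inhibition, read by sulforhodamine B assay, with a stated time of 48 h (a higher number here means that more compound is tolerated, a lower number that less compound is tolerated), compound 3 gives 6920 nM. Compound 1 `Nc1cc(N)c2nc(-c3ccccc3)c(NCc3ccc(Cl)c(Cl)c3)nc2c1` gives 83200 nM in this assay, so there is a 12-fold lower number from compound 1 to compound 3 (1.08 log units; beyond the scatter). Compound 2 `COc1ccc(CNc2nc3cc(N)cc(N)c3nc2-c2ccccc2)cc1OC` reaches only a limit in this assay, < 100000 nM. Among the readable numbers compound 3 thus stands lowest. Compound 4 `Nc1cc(N)c2nc(-c3ccccc3)c(Oc3ccc(F)cc3)nc2c1` differs from compound 3 by 4-fluorophenoxy in place of (4-fluorobenzyl)amino on an aromatic carbon. Going by the values given here, none of the measured steps touches this change: the step from compound 1 to compound 3, and the two steps left unreadable by the limit, swap only the aryl group and leave the rest untouched. With nothing bearing on the change, the number for compound 4 is expected to remain near that of compound 3, with a wide range, a 1.4-fold higher number from compound 3 to compound 4 (0.16 log units; within the scatter). The estimate for compound 4 is 10000 nM, between 2500 nM and 50000 nM.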

Compound 4, concentration lethal to 50% of the cells: 70800 nM
Compound 4: the middle estimate sits 7.1-fold (0.85 log units) below what was measured; measured number above the stated range.
By their numbers in this assay, from the lowest: compound 3; then compounds 4 and 1 (each within the scatter of the next).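

The earlier steps shown here swapped only the aryl group; this one shows that the link to the shared core also counts, giving a 10-fold higher number from compound 3 to compound 4 (1.01 log units; beyond the scatter) in this assay while the 4-fluorophenyl ring stays. Compound 4 thereby loses the low standing of compound 3, and its number lies within the scatter of that of compound 1. Nothing measured here gives a cause for this step. The compounds shown leave open whether the oxygen or the lost chain carbon carries the step: a 4-fluorobenzyloxy or 4-fluoroanilino group at this aromatic carbon would separate the two.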